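The source may report more compounds than this note shows. Statements on the series, on what has been measured and on what is new or still open speak of the compounds shown alone.

Compound 3 `CC1CCC(C(=O)N2CCc3nc(C#Cc4ccccc4)sc3C2)CC1` carries a 4-methylcyclohexyl on the carbonyl carbon of the shared core. In an assay on HEK293 cells for negative allosteric modulation of metabotropic glutamate receptor 5 (Homo sapiens), read by FLIPR, with a stated time of 1 h (on this read-out lower numbers stand for stronger inhibition and higher numbers for weaker inhibition), compound 3 gives > 10000 nM, which is a limit of the assay and not a number. Compound 1 `CC(=O)N1CCc2nc(C#Cc3ccccc3)sc2C1`, with a methyl on that carbon, gives 90 nM in this assay. Compound 2 `O=C(C1CC(F)C1)N1CCc2nc(C#Cc3ccccc3)sc2C1`, with a 3-fluorocyclobutyl there, gives > 10000 nM in this assay, and this too is a limit. The two measured steps that start from compound 1 are both large: an at least 110-fold higher number from compound 1 to compound 2 (2.04 log units; beyond the scatter) and an at least 110-fold higher number from compound 1 to compound 3 (2.04 log units; beyond the scatter). Between the two ring amides the comparison is a step that the two limits leave unreadable from compound 2 to compound 3, since (the limit of > 10000 nM in this assay, at which 2 of the 3 values shown sit).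

Compound 4 `O=C(c1cccc(Cl)c1)N1CCc2nc(C#Cc3ccccc3)sc2C1` differs from compound 3 by 3-chlorophenyl in place of 4-methylcyclohexyl on a carbonyl carbon. Both readable steps describe a methyl growing into a ring, and neither compares a non-aromatic ring with an aromatic one, so where compound 4 lands relative to compound 3 cannot be read from them. The step of an at least 3.3-fold lower number from compound 3 to compound 4 (0.52 log units; beyond the scatter) is therefore only a broad estimate. Compound 4 is expected to give about 3000 nM in this assay, within a range from 200 nM to 20000 nM.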

Compound 4, half-maximal inhibitory concentration: > 10000 nM
Compound 4: a limit, no number; the forecaster's own chance of this, stated with the estimate: 50%; middle value at least 3.3-fold (0.52 log units) away from the limit.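

The 3-chlorophenyl group behaves like the two non-aromatic rings: in this assay replacing the methyl gives an at least 110-fold higher number from compound 1 to compound 4 (2.04 log units; beyond the scatter). The large step away from the methyl amide is thus seen with an aromatic ring as well, and compound 1 remains the only one of the four with a readable value. The steps among compound 2, compound 3 and compound 4 cannot be read, because all three stand at one limit of the assay and not at numbers: the limit of > 10000 nM in this assay, at which 3 of the 4 values shown sit.

From the compounds shown here alone, how the three ring amides rank against one another stays open. So does the question of whether a group only slightly larger than methyl on this carbonyl carbon, such as an ethyl or a cyclopropyl, keeps a readable value.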